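The source may report more compounds than this note shows. Statements on the series, on what has been measured and on what is new or still open speak of the compounds shown alone.

Compound 1 `O=C([C@@H]1CCCN(S(=O)(=O)c2ccc(S(=O)(=O)C3CCC3)cc2)C1)N1CCC(F)(F)CC1` gives 9 nM in a functional assay on MIA PaCa-2 cells (Homo sapiens) for inhibition, read by MTT assay, with a stated time of 7 days (on this read-out lower numbers stand for stronger inhibition and higher numbers for weaker inhibition), and stands lowest, that is strongest, of the three measured compounds. Within the data shown here, compound 2 `CCN(CC)S(=O)(=O)c1ccc(S(=O)(=O)N2CCC[C@@H](C(=O)N3CCC(OC)CC3)C2)cc1` gives 140 nM and compound 3 `CCN(CC)S(=O)(=O)c1ccc(S(=O)(=O)N2CCC[C@@H](C(=O)N3CCC(C(F)(F)F)CC3)C2)cc1` gives 320 nM; the only single-point comparison among them is a 2.3-fold higher number from compound 2 to compound 3 (0.36 log units; beyond the scatter), and it concerns the amide ring, not the sulfonyl group. Compound 4 `O=C([C@@H]1CCCN(S(=O)(=O)c2ccc(S(=O)(=O)N3CC[C@H](O)C3)cc2)C1)N1CCC(F)(F)CC1` differs from compound 1 by 3-hydroxypyrrolidin-1-yl in place of cyclobutyl on a sulfonyl sulfur. Among the measured compounds shown here, no measured step touches this place, so the expectation rests on compound 1 alone, and the value of compound 2 and compound 3 shows only that other sulfonyl groups reached weaker numbers within a different amide series. Compound 4 is therefore expected to weaken somewhat, a 2.8-fold higher number from compound 1 to compound 4 (0.44 log units; beyond the scatter), to an estimated 25 nM within 6 nM to 100 nM.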

Compound 4, half-maximal inhibitory concentration: 590 nM
Estimate against measurement, compound 4: 24-fold (1.37 log units) below; measured number outside the range, above it.
By their numbers in this assay, from the lowest: compound 1; then compound 2; then compounds 3 and 4 (each within the scatter of the next).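

The sulfonyl position tolerates this change poorly: 3-hydroxypyrrolidin-1-yl in place of cyclobutyl on the sulfonyl sulfur gives a 66-fold higher number from compound 1 to compound 4 (1.82 log units; beyond the scatter), with the rest of the molecule unchanged. This first measured step at this place is far larger than the earlier step on the amide ring, a 2.3-fold higher number from compound 2 to compound 3 (0.36 log units; beyond the scatter). Nothing available explains the size of this loss.

Going by these compounds, this single step changes the ring, the atom bonded to sulfur and the hydroxyl together, so their separate contributions remain open. Plain pyrrolidin-1-yl or cyclopentyl on the same sulfonyl sulfur would begin to separate them.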